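The source may report more compounds than this note shows. Statements on the series, on what has been measured and on what is new or still open speak of the compounds shown alone.

Compound 1 `OCc1ccc(-c2nn(Cc3cccnc3)c3ccccc23)o1` and compound 2 `CCCCCc1cnc(-c2nn(Cc3ccccc3F)c3ncccc23)nc1N` are the two measured compounds. In a functional assay (aorta) with Oryctolagus cuniculus as the target (a lower number here means a stronger inhibitor, a higher number a weaker inhibitor), compound 1 gives 9600 nM, and in this assay compound 2 gives 200000 nM, the higher of the two numbers, the gap between them lying beyond the scatter. Compound 3 `CS(=O)(=O)c1cnc(-c2nn(Cc3ccccc3F)c3ncccc23)nc1N` has not yet been measured; it differs from compound 2 by methylsulfonyl in place of pentyl on an aromatic carbon. Going by the values given here, no measured pair shows this change, so the expected step of a 2.0-fold lower number from compound 2 to compound 3 (0.30 log units; within the scatter) is small and of uncertain direction. For compound 3 in this assay the estimate is 100000 nM, expected to lie between 20000 nM and 400000 nM.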

Compound 3, half-maximal inhibitory concentration: 261000 nM
Compound 3: middle estimate off by 2.6-fold (0.42 log units), on the low side; low and high end bracket the measured number.
By their numbers in this assay, from the lowest: compound 1; then compounds 2 and 3 (each within the scatter of the next).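

In this assay, methylsulfonyl in place of pentyl on this aromatic carbon, ortho to an amino group, gives a 1.3-fold higher number from compound 2 to compound 3 (0.12 log units; within the scatter). Going by these compounds alone, the first measured pair at this position therefore shows that this exchange of groups, which differ in atoms and hydrogen-bond acceptors, does not separate the two compounds beyond the scatter. Nothing available accounts for this result.

From the compounds shown here alone, whether a carboxylic acid, an amine or a longer chain on this carbon would separate from compound 2 remains open. So does whether this exchange would read the same if the neighbouring amino group were replaced by a methyl group.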